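This account rests on a few compounds, and the source may have more. Where it says the series, first, only, none or still open, it means among the compounds named here.

Among the compounds with values here, only two compounds have entries so far, compound 1 `Nc1ccccc1NC(=O)c1ccc(COc2ccc([N+](=O)[O-])cc2)cc1` and compound 2 `O=C(/C=C/c1ccc(CN2CCc3ccccc32)cc1)NO`, and neither gives a single number. In a functional assay on MGC-803 cells (Homo sapiens) for antiproliferative activity, read by CCK-8 assay, with a stated time of 72 h (a lower number here means a stronger inhibitor, a higher number a weaker inhibitor), compound 1 gives > 32000 nM. That value is a limit of the assay, not a measured number. In this assay compound 2 carries the entry "not determined" (no result reported), so it offers no comparison.

Attention therefore turns to compound 3 `CCc1ccc(OCc2ccc(C(=O)Nc3ccccc3N)cc2)cc1`, which has yet to be measured. It keeps the core of compound 1 and differs in one place, on an aromatic carbon para to a large group, where ethyl stands in place of nitro: ethyl in place of nitro on an aromatic carbon. Within the data shown here, no measured pair shows what this exchange does in this assay, so the expectation rests on the limit alone. The estimated step of an at least 1.4-fold lower number from compound 1 to compound 3 (0.16 log units; that floor lies within the scatter) is expected to be small, with no direction beyond the scatter, and compound 3 may also reach the limit of the assay. The expected value for compound 3 is 22000 nM, with an estimated range from 6000 nM to 60000 nM.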

Compound 3, half-maximal inhibitory concentration: 5880 nM
The estimate for compound 3 lay 3.7-fold (0.57 log units) above the measured number, outside the stated range (below it).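

In this assay this position now has a measured effect: ethyl in place of nitro on an aromatic carbon, para to a large group, gives an at least 5.4-fold lower number from compound 1 to compound 3 (0.73 log units; beyond the scatter). Compound 3 is also the first compound shown with a single number, so the shared core does register in this read-out once 4-nitrophenyl has become 4-ethylphenyl. The step gives only a lower bound on the size of the change, since the entry for compound 1 is a limit of the assay and not a number: the limit of > 32000 nM in this assay, at which 1 of the 3 values shown sits.

A single exchange at a single position cannot separate what the entering ethyl contributes from what the departing nitro removes, and a methoxy group, a chlorine or a longer chain at the same carbon would be needed to tell the two apart. From the compounds shown here alone, compound 2 has no result to add, and whether an amine or a carboxylic acid at this place would move the number further, in either direction, stays open.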